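Capping the Chain End: From Compound 1 to Compound 3

The compounds below may be only part of what the source reports. "The series", "measured", "known", "first", "only" and "open" are said of these compounds alone.

Measured so far:
compound 1 `Cn1c(=O)c(C(=O)NCCCCCCN)c(O)c2ccccc21`: 3.1%
compound 2 `Cn1c(=O)c(C(=O)Nc2ccccc2N)c(O)c2ccccc21`: 6%

Among the compounds with values here, in a functional assay, with a stated time of 20 min, tested at 0.1 mM (on this read-out lower numbers stand for a weaker effect and higher numbers for a stronger effect at the one concentration tested), compound 1 stands lowest of the two numbers, yet the one step measured, a number 2.9 percentage points higher from compound 1 to compound 2 (within the scatter), lies inside the usual scatter, so the two compounds cannot be told apart on this read-out. Compound 3 `Cn1c(=O)c(C(=O)NCCCCCCNC(=O)CCCCC2CCSS2)c(O)c2ccccc21` arises from compound 1 by a group of 11 heavy atoms (8 carbon, 1 oxygen, 2 sulfur; one five-membered non-aromatic ring with 2 hetero atoms) in place of a hydrogen atom, on an amine nitrogen. Within the data shown here, the only measured step concerns a different change, the 2-aminophenyl in place of the 6-aminohexyl, and so says nothing about the group entering here; no measured step bears on the change from compound 1 to compound 3. With both measured values low and no guidance from the data, a step of about a number 1.9 percentage points higher from compound 1 to compound 3 (within the scatter) is expected, that is, none beyond the scatter. Compound 3 is therefore estimated at 5%, within a range from 0% to 20%.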

Compound 3, a percentage reported as activity, at one concentration (the size of the read-out at that concentration, not a potency): 9.1%
Compound 3: the middle estimate sits 4.1 percentage points below what was measured, and the stated range covers the measured number.
By their numbers in this assay, from the lowest: compounds 1, 2 and 3 (each within the scatter of the next).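

In this assay, placing a group of 11 heavy atoms, including one five-membered non-aromatic ring with 2 hetero atoms, on the amine nitrogen gives a number 6 percentage points higher from compound 1 to compound 3 (within the scatter). Unlike the earlier swap of 6-aminohexyl for 2-aminophenyl, this change keeps the chain and alters only the amine nitrogen, and even a group of this size, with its 2 sulfur atoms, leaves the read-out inside the usual scatter. Nothing measured here offers a reason for this result.

As far as these compounds go, it remains open whether the ring or the carbonyl-bearing chain that carries it matters at all, and a simple acetyl group on the same nitrogen would test this. Also open, from the compounds shown here alone, is whether a longer chain between the shared core and this nitrogen would move the read-out beyond the scatter.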